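The source may report more compounds than this note shows. Statements on the series, on what has been measured and on what is new or still open speak of the compounds shown alone.

Measured in an ADME assay on a cell-free system (plasma, Mus musculus) for protein binding:
compound 1 `CNc1nccc(N2CC[C@H](NC(=O)Nc3ccc(OC(F)F)cc3)C2)n1` gives 96.8%;
compound 2 `CNc1nccc(N2CC[C@H](NC(=O)Nc3ccc(CN4CCN(C)CC4)c(C(F)(F)F)c3)C2)n1` gives 85.8%;
compound 3 `CNc1nccc(N2CC[C@H](NC(=O)Nc3ccc(OC)cc3)C2)n1` gives 82.1%.

On the unbound fraction compound 2 stands second of the three values: close to compound 3, within the scatter, and well apart from compound 1, beyond the scatter. Within the data shown here, the only single-point step known, a 5.6-fold higher unbound fraction from compound 1 to compound 3 (0.75 log units; beyond the scatter), concerns the group on the oxygen and not the part of the molecule changed here. Compound 4 `CNc1nccc(N2CC[C@H](NC(=O)Nc3ccc(CN4CCC4)c(C(F)(F)F)c3)C2)n1` differs from compound 2 by azetidin-1-yl in place of 4-methylpiperazin-1-yl on a saturated chain carbon bound to an aromatic carbon. Among the measured compounds shown here, no measured step bears on this change, so any expectation rests on the structures alone and carries wide uncertainty. Compound 4 is expected to show somewhat more binding than compound 2, with the estimated step being a 1.4-fold lower unbound fraction from compound 2 to compound 4 (0.15 log units; within the scatter). The estimate for compound 4 in this assay is 90%, with a range of 80% to 96%.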

Compound 4, plasma protein binding: 85.6%
Compound 4: middle estimate off by 1.4-fold (0.16 log units) (unbound fraction), on the low side; the measured number falls inside the stated range.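

In this assay, among these compounds, the first step at this position, on a saturated chain carbon bound to an aromatic carbon, is a 1.0-fold higher unbound fraction from compound 2 to compound 4 (0.01 log units; within the scatter), which lies within the scatter. Azetidin-1-yl and 4-methylpiperazin-1-yl therefore cannot be told apart here, despite the difference in ring size and in hetero atoms. Nothing measured accounts for this result.

Open, on these data alone, is whether a morpholine, a primary amine or a carboxylic acid in the same place would move the read-out beyond the scatter. Also open, as far as these compounds go, is how a longer chain between the aromatic ring and the amine would read.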